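The source may report more compounds than this note shows. Statements on the series, on what has been measured and on what is new or still open speak of the compounds shown alone.

Compound 1 `COc1ccc(OC)c2c1C(=O)C=C(CO)C2=O` carries a hydroxymethyl on the shared core. In a functional assay on L1210 cells (Mus musculus) for cytotoxicity (on this read-out higher numbers stand for an effect only at larger amounts of compound and lower numbers for an effect already at smaller amounts), compound 1 gives 0.524 ug/mL. Within the data shown here, compound 2 `CCCCCCCC(O)c1cc(OC)c2c(c1OC)C(=O)C=CC2=O` is the only other measured member of the series; in this assay compound 2 gives 0.274 ug/mL. Among these two numbers compound 1 does not stand apart: its gap to compound 2 lies within the scatter, so the two values cannot be ordered. Compound 3 `COc1ccc(OC)c2c1C(=O)C=C(C(C)O)C2=O` is not yet measured. Relative to compound 1 the change is methyl in place of hydrogen on a saturated chain carbon bound to a double-bonded ring carbon and an oxygen on a saturated carbon. Among the measured compounds shown here, no measured pair shows this kind of change, and the one comparison available, compound 1 against compound 2, is itself within the scatter. A step from compound 1 to compound 3 of a 1.0-fold lower number from compound 1 to compound 3 (0.02 log units; within the scatter) is expected, none beyond the scatter in either direction. For compound 3 in this assay the estimate is 0.5 ug/mL, within 0.2 ug/mL to 1.3 ug/mL.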

Compound 3, concentration for half-maximal effect: 0.487 ug/mL
Compound 3: the middle estimate sits 1.0-fold (0.01 log units) above what was measured; low and high end bracket the measured number.
By their numbers in this assay, from the lowest: compounds 2, 3 and 1 (each within the scatter of the next).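

Hydroxymethyl to 1-hydroxyethyl gives the series its first readable step at one place, on a saturated chain carbon bound to a double-bonded ring carbon and an oxygen on a saturated carbon: in this assay the change gives a 1.1-fold lower number from compound 1 to compound 3 (0.03 log units; within the scatter). This single step shows that methyl in place of hydrogen at this carbon leaves no difference that can be told from the scatter, which the earlier comparison of compound 1 with compound 2, two compounds differing in more than one place, could not show. No measurement on hand offers an explanation for this result.

As far as these compounds go, whether a longer chain or a phenyl group at this carbon would give a step beyond the scatter remains open. Also open, from the compounds shown here alone, is what an amine or a carboxylic acid in place of the hydroxyl would do.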